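From azetidine to pyrrolidine: a smaller step expected

This account rests on a few compounds, and the source may have more. Where it says the series, first, only, none or still open, it means among the compounds named here.

Values measured so far in an ADME assay on a cell-free system (plasma, Homo sapiens) for protein binding, are:
Compound 1 `CNc1nccc(N2CC[C@H](NC(=O)Nc3ccc(Cl)c(C(F)(F)F)c3)C2)n1` gives 99.8%
Compound 2 `CNc1nccc(N2CC[C@H](NC(=O)Nc3ccc(CN4CCC4)c(C(F)(F)F)c3)C2)n1` gives 86.3%

Of the two measured compounds, compound 2 holds the higher unbound fraction. For the measured compounds named here, the one measured step is a 69-fold higher unbound fraction from compound 1 to compound 2 (1.84 log units; beyond the scatter). In that step, (azetidin-1-yl)methyl replaced chloro on an aromatic carbon.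

The next compound is compound 3 `CNc1nccc(N2CC[C@H](NC(=O)Nc3ccc(CN4CCCC4)c(C(F)(F)F)c3)C2)n1`, and its change from compound 2 is pyrrolidin-1-yl in place of azetidin-1-yl on a saturated chain carbon bound to an aromatic carbon. In plain terms, pyrrolidin-1-yl stands in place of azetidin-1-yl on a saturated chain carbon bound to an aromatic carbon. The same difference reads (azetidin-1-yl)methyl to (pyrrolidin-1-yl)methyl.

Going by the values given here, no measured step swaps one such ring for another, so the large step above bears on this change only loosely. It replaced chloro with a whole new group, whereas here one non-aromatic ring with a single nitrogen gives way to another. Starting from compound 2 at 86.3%, no step beyond the scatter is expected in this assay. The expected change is a 1.2-fold lower unbound fraction from compound 2 to compound 3 (0.10 log units; within the scatter). For compound 3 the estimate is 89%, with an expected range from 80% to 95%.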

Compound 3, plasma protein binding in the Homo sapiens assay: 86.5%
Estimate against measurement, compound 3: 1.2-fold (0.09 log units) (unbound fraction) below; the measured number falls inside the stated range.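

In the Homo sapiens assay, exchanging azetidin-1-yl for pyrrolidin-1-yl on the saturated chain carbon bound to an aromatic carbon has no readable effect, the step being a 1.0-fold lower unbound fraction from compound 2 to compound 3 (0.01 log units; within the scatter). The large difference from the chloro group is thus not tied to azetidin-1-yl alone, as the second ring also gives a 68-fold higher unbound fraction from compound 1 to compound 3 (1.83 log units; beyond the scatter). In a physicochemical assay for solubility, measured as kinetic solubility (on this read-out lower numbers stand for lower solubility and higher numbers for higher solubility), compound 2 gives 84900 nM and compound 3 gives 37400 nM. The same exchange does register in the physicochemical assay, where the pyrrolidin-1-yl compound is modestly less soluble, so this position tolerates the change in one read-out but not in the other: the measured solubility of compound 2, 84900 nM, and of compound 3, 37400 nM, a 2.3-fold lower number (0.36 log units; beyond the scatter)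

With only these two rings, the compounds shown cannot tell whether the unbound fraction stays level across other amines at this position, such as piperidine, morpholine or an open-chain dimethylamino group. Nor can they tell whether the solubility difference follows ring size or is particular to this pair.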